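Two More Carbons on the Side Chain

This account rests on a few compounds, and the source may have more. Where it says the series, first, only, none or still open, it means among the compounds named here.

Compound 1, `N#CNC(=N)Nc1cccnc1`: 50 mg/kg
Compound 2, `CCCCC/N=C(\NC#N)Nc1cccnc1`: 20 mg/kg
Compound 3, `CC(C)(C)C/N=C(/NC#N)Nc1cccnc1`: 2.5 mg/kg

These three compounds share one core and were all tested in a functional assay on the whole organism (blood, strain Wistar-Okamoto) with Rattus norvegicus as the target, with a stated time of 5 days; a lower number here means that less compound is needed, a higher number that more compound is needed for the effect. Compound 2 stands second highest of the three numbers: compound 1 gives a higher number than compound 2, and compound 3 a lower one, and both differences are beyond the usual scatter of this assay.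

Compound 4, `CCCCCCC/N=C(\NC#N)Nc1cccnc1`, has not yet been measured in this assay. It differs from compound 2 in a single place: ethyl in place of hydrogen on a saturated chain carbon, five bonds along the chain from a double-bonded nitrogen. Going by the values given here, no pair of measured compounds isolates this particular change. Among the compounds with values here, the only related comparison is compound 1 against compound 2, which differ by the whole pentyl chain and where compound 2 gives the lower number, so lengthening the chain further may lower the number a little more or leave it within the scatter.

Compound 4 is therefore expected at about 15 mg/kg, within a range from 6 mg/kg to 40 mg/kg. The step of a 1.3-fold lower number from compound 2 to compound 4 (0.12 log units; within the scatter) that this estimate means is expected to be small, at or barely beyond the scatter.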

Compound 4, minimum effective dose: > 50 mg/kg
Compound 4 ended at the assay's limit (the forecaster's own chance of this, stated with the estimate: 5%); middle value at least 3.3-fold (0.52 log units) away from the limit.
By their numbers in this assay, from the lowest: compound 3; then compound 2; then compound 1.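

Compound 4 gives > 50 mg/kg in this assay, which is a limit of the assay and not a number. Ethyl in place of hydrogen on a saturated chain carbon, five bonds along the chain from a double-bonded nitrogen, thus produces an at least 2.5-fold higher number from compound 2 to compound 4 (0.39 log units; beyond the scatter), so this small extension costs activity rather than leaving it unchanged. Chain length here therefore does not act in one direction: compound 2, with its pentyl chain, gives a lower number than compound 1, which has no such chain, whereas the longer chain of compound 4 reverses that trend.

From the compounds shown here alone, the full size of the step stays open, since the result for compound 4 is a limit: the limit of > 50 mg/kg in this assay, at which 1 of the 4 values shown sits. Also open is how a hexyl chain would compare with compound 2 and compound 4, and whether an amine on the chain would bring the number back down.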